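From hydrogen to nitro on a shared core

The source may hold more compounds than are shown below. What is called first, only, known or untested is meant among the compounds shown, and "the series" means these compounds.

Measured in a functional assay on SH-SY5Y cells (Homo sapiens) for cytotoxicity, read by MTT assay, with a stated time of 48 h (a lower number here means a stronger inhibitor, a higher number a weaker inhibitor), so far:
- compound 1 `COc1cc(/C=C/C(=O)/C=C/c2nc3ccccc3n2C)ccc1O` at 4700 nM as its half-maximal inhibitory concentration
- compound 2 `COc1cc(/C=C/C(=O)/C=C/c2nc3cc(Cl)ccc3n2C)ccc1O` at 4700 nM as its half-maximal inhibitory concentration

Compound 1 stands level with compound 2 on these numbers, so neither can be ranked above the other. The next molecule to be tested, compound 3 `COc1cc(/C=C/C(=O)/C=C/c2nc3cc([N+](=O)[O-])ccc3n2C)ccc1O`, keeps the core of compound 1 and makes one change: nitro in place of hydrogen on an aromatic carbon. In plain terms, this is nitro in place of hydrogen on an aromatic carbon.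

Among the compounds with values here, only one measured step bears on this change. It is no change at the digits printed from compound 1 to compound 2 (within the scatter) and it lies within the scatter. That step also replaces a hydrogen on an aromatic carbon, which gives some reason to expect a small effect here too. Within the data shown here, it is thin evidence, though, since chloro and nitro are different groups and no nitro compound has been measured yet. No step beyond the scatter is expected in this assay, and the data favour no clear direction. The expected change is a 1.1-fold lower number from compound 1 to compound 3 (0.05 log units; within the scatter) and nothing firmer can be said. In this assay compound 3 is estimated at 4200 nM with 1800 nM to 9500 nM as the expected range.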

Compound 3, half-maximal inhibitory concentration: 4600 nM
Compound 3: middle estimate off by 1.1-fold (0.04 log units), on the low side; low and high end bracket the measured number.
By their numbers in this assay, from the lowest: compounds 3, 1 and 2 (each within the scatter of the next).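

In this assay, nitro in place of hydrogen on an aromatic carbon gives a 1.0-fold lower number from compound 1 to compound 3 (0.01 log units; within the scatter), and nitro in place of chloro at the same place gives a 1.0-fold lower number from compound 2 to compound 3 (0.01 log units; within the scatter). Until now this position rested on a single replacement, chloro, so the flat result could have been particular to that one group; a second, quite different group now gives the same picture. Hydrogen, chloro and nitro at this place on the shared core cannot be told apart by this read-out, and nothing measured here offers an explanation for that.

Going by these compounds, three compounds are a narrow sample, so it remains open whether an amine, a carboxylic acid or a longer chain at this same place would also leave the number within the scatter, or whether this position can move it at all. Also open is whether changes elsewhere on the shared core would shift the number, and whether the sameness seen here extends beyond this assay to any other measure of these compounds.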